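The source may report more compounds than this note shows. Statements on the series, on what has been measured and on what is new or still open speak of the compounds shown alone.

In a functional assay on cells for positive allosteric modulation of G-protein coupled receptor 68 (Homo sapiens), read by a luciferase reporter and cAMP accumulation, with a stated time of 30 min, at pH 6.8 and pH 8.3, in the presence of a further agent that is not named here (on this read-out lower numbers stand for lower potency and higher numbers for higher potency (the scale is a negative logarithm)), compound 1 `Nc1nc(NCc2ccccc2)nc(-c2ccccc2CO)n1` gives 4.35. For the measured compounds named here, compound 2 `CCNc1nc(NCc2ccccc2)nc(-c2ccccc2CO)n1` gives 4.63 in this assay, and the one step connecting the two, a number 0.28 log units higher from compound 1 to compound 2 (within the scatter), lies within the scatter, so the two cannot be told apart. Going by the values given here, the only other compound, compound 3 `CC(=O)c1ccccc1-c1nc(N)nc(NCc2ccccc2)n1`, was reported in this assay as "not active" (no number reported), with no number attached. Compound 1 therefore stands with one of the two numbers given, neither of which separates from the other.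

Compound 4 `Nc1nc(NCc2ccccc2)nc(-c2ccc(Cl)cc2CO)n1` differs from compound 1 in one place: chloro in place of hydrogen on an aromatic carbon. Among the compounds with values here, no measured step touches the ring that carries the hydroxymethyl group, so nothing among the numbers given shows what adding a chloro there does. The step from compound 1 to compound 2, a number 0.28 log units higher from compound 1 to compound 2 (within the scatter), concerns a different part of the molecule and only shows that one small change left the number within the scatter.

For compound 4 the step of a number 0.05 log units higher from compound 1 to compound 4 (within the scatter) is expected, with the estimate 4.4 and a range from 3.9 to 5.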

Compound 4, negative logarithm of the antagonist equilibrium constant: 4.76
The estimate for compound 4 lay 0.36 log units below the measured number; the measured number falls inside the stated range.
By their numbers in this assay, from the lowest: compounds 1, 2 and 4 (each within the scatter of the next, the first and the last beyond it).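

Chloro in place of hydrogen on this aromatic carbon, meta to the hydroxymethyl group and para to a large group, gives a number 0.41 log units higher from compound 1 to compound 4 (beyond the scatter) in this assay and so provides the first step in this small set that clears the scatter. The position on the hydroxymethyl-bearing ring can therefore take a chlorine atom without loss of potency, and the number even rises modestly. For the compounds shown here, until now, the only step with a number concerned a different part of the molecule and stayed within the scatter.

The compounds shown leave open whether a methoxy group, a carboxylic acid or an amine at this same carbon would behave like chloro. They also leave open whether chloro would give a similar step when added to compound 2. No measurement given here explains why the chloro step occurs.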